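The source may report more compounds than this note shows. Statements on the series, on what has been measured and on what is new or still open speak of the compounds shown alone.

In a functional assay on the whole organism (artery, strain albino) with Rattus norvegicus as the target, with a stated time of 900 min, at a dose of 10 mg/kg by the oral route (on this read-out higher numbers stand for more inhibition at the one dose given (going by the name of the read-out) and lower numbers for less inhibition), the measured compounds are: compound 1 `CC1=C(C(=O)Nc2ccc([N+](=O)[O-])cc2)C(c2ccc(Br)cc2)N=C(SCc2ccc(F)cc2)N1`, 22.6%; compound 2 `CC1=C(C(=O)Nc2ccc([N+](=O)[O-])cc2)C(c2cccc([N+](=O)[O-])c2)N=C(SCc2ccccc2Cl)N1`, 7.2%; compound 3 `CC1=C(C(=O)Nc2ccc([N+](=O)[O-])cc2)C(c2cccc([N+](=O)[O-])c2)N=C(SCc2cccc(Cl)c2)N1`, 10.8%.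

Compound 3 stands second highest of these three numbers; compound 2 is nearest, within the scatter, and compound 1 is furthest, beyond it. Compound 4 `CC1=C(C(=O)Nc2ccc([N+](=O)[O-])cc2)C(c2cccc([N+](=O)[O-])c2)N=C(SCc2ccc(F)cc2)N1` differs from compound 3 by 4-fluorophenyl in place of 3-chlorophenyl on a saturated chain carbon bound to a sulfur. Going by the values given here, the only measured step at this position is a number 3.6 percentage points higher from compound 2 to compound 3 (within the scatter), which lies within the scatter. Compound 1 also carries the 4-fluorobenzyl group and gives 22.6% in this assay, but it differs from compound 4 in a second place as well, so it is only a hint. The expected step is therefore small, a number 2.2 percentage points higher from compound 3 to compound 4 (within the scatter), not beyond the scatter. Compound 4 is estimated at 13%, from 3% to 25%.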

Compound 4, a percentage reported as inhibition, in the whole organism at one dose (the size of the read-out at that dose, not a potency): 15.4%
The estimate for compound 4 lay 2.4 percentage points below the measured number; low and high end bracket the measured number.
By their numbers in this assay, from the lowest: compounds 2, 3, 4 and 1 (each within the scatter of the next, the first and the last beyond it).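

In this assay the 4-fluorophenyl on a saturated chain carbon bound to a sulfur cannot be told apart from either chlorophenyl, with a number 4.6 percentage points higher from compound 3 to compound 4 (within the scatter) and with a number 8.2 percentage points higher from compound 2 to compound 4 (within the scatter) as well. At the saturated ring carbon, 3-nitrophenyl in place of 4-bromophenyl gives a number 7.2 percentage points lower from compound 1 to compound 4 (within the scatter) and so also shows no change that can be read. Nothing measured here explains these numbers. On these data alone, it remains open whether an aminophenyl or a carboxyphenyl in place of the 4-fluorophenyl would move the number beyond the scatter. As far as these compounds go, a longer chain between the sulfur and the ring also remains open.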